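The source may hold more compounds than are shown below. What is called first, only, known or untested is meant among the compounds shown, and "the series" means these compounds.

The measured compounds in an assay on isolated protein for inhibition of protoporphyrinogen oxidase (Homo sapiens), read by capillary electrophoresis; on this read-out lower numbers stand for stronger inhibition and higher numbers for weaker inhibition:

Compound 1, `CCOC(=O)CCCSc1nc2cc(-n3nc(C(C)(C)C)sc3=O)c(Cl)cc2s1`, gives 17700 nM.
Compound 2, `C#CCSc1nc2cc(-n3nc(C(C)(C)C)sc3=O)c(Cl)cc2s1`, gives 21400 nM.
Compound 3, `CCOC(=O)CCCSc1nc2cc(-n3nc(C(C)(C)C)sc3=O)c(Br)cc2s1`, gives 245000 nM.

Compound 4, `C#CCSc1nc2cc(-n3nc(C(C)(C)C)sc3=O)c(Br)cc2s1`, has not yet been measured in this assay. It is reached from compound 3 by one change, (ethynyl in place of 2-(ethoxycarbonyl)ethyl on a saturated chain carbon bound to a sulfur). The same change, at the same place, has already been made once among the measured compounds, from compound 1 to compound 2, where it reads ethynyl in place of 2-(ethoxycarbonyl)ethyl on a saturated chain carbon bound to a sulfur and produced a step of a 1.2-fold higher number from compound 1 to compound 2 (0.08 log units; within the scatter), a step that does not stand out from repeat measurements.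

Compound 3 and compound 4 share a core that differs from the core of compound 1 and compound 2 in one point, (bromo in place of chloro on an aromatic carbon). That difference carried a large step, a 14-fold higher number from compound 1 to compound 3 (1.14 log units; beyond the scatter), and leaves compound 3 with the highest number of the three measured compounds.

Within the data shown here, for compound 4 the step from compound 3 is expected to be a 1.2-fold higher number from compound 3 to compound 4 (0.07 log units; within the scatter), small and of the same kind as the earlier one, because the one measured instance of this change, a 1.2-fold higher number from compound 1 to compound 2 (0.08 log units; within the scatter), barely moved the number. On that basis compound 4 is expected to give about 290000 nM in this assay. The estimated range for compound 4 runs from 110000 nM to 800000 nM.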

Compound 4, inhibition constant: 20700 nM
For compound 4 the middle estimate is 14-fold (1.15 log units) above the measured one; measured number outside the range, below it.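

In this assay, ethynyl in place of 2-(ethoxycarbonyl)ethyl on a saturated chain carbon bound to a sulfur gave a 12-fold lower number from compound 3 to compound 4 (1.07 log units; beyond the scatter) on the core carrying bromo, so the near-silent step seen on the core carrying chloro did not carry over: the same change on two cores in this assay, a 1.2-fold higher number (0.08 log units; within the scatter) from compound 1 to compound 2 and a 12-fold lower number (1.07 log units; beyond the scatter) from compound 3 to compound 4, 14-fold (1.16 log units) apart, beyond the scatter of two such steps. Read the other way, bromo in place of chloro, a large step with the 2-(ethoxycarbonyl)ethyl group present, gave a 1.0-fold lower number from compound 2 to compound 4 (0.01 log units; within the scatter) with ethynyl present, so neither change has a size of its own that holds on both cores: the same change on two cores in this assay, a 14-fold higher number (1.14 log units; beyond the scatter) from compound 1 to compound 3 and a 1.0-fold lower number (0.01 log units; within the scatter) from compound 2 to compound 4, 14-fold (1.16 log units) apart, beyond the scatter of two such steps. Among these compounds, the mismatch centres on compound 3, the only one of the four compounds with both bromo and 2-(ethoxycarbonyl)ethyl, but these two pairs show only that the steps are not additive here, not what lies behind this or whether it extends to other compounds.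

The compounds shown leave open whether the weak number of compound 3 is tied to the ester or to chain length, which a carboxylic acid in place of the ester or a plain butyl chain on the same core would separate. They also leave open how a fluoro or a methyl in place of bromo would behave with each of the two chains.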